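This account rests on a few compounds, and the source may have more. Where it says the series, first, only, none or still open, it means among the compounds named here.

Among the compounds with values here, in a functional assay for antagonist activity at transient receptor potential cation channel subfamily V member 1 (Homo sapiens), read by calcium flux (a lower number here means a stronger inhibitor, a higher number a weaker inhibitor), compound 3 `O=C(Nc1cccc2[nH]ncc12)NC1CCOc2c(C3CCCCC3)cccc21` gives 15 nM, the upper end of the three numbers so far. Compound 1 `O=C(Nc1cccc2[nH]ncc12)NC1CCOc2cc(OC(F)(F)F)ccc21` gives 8 nM in this assay, within the scatter of compound 3, while compound 2 `O=C(Nc1cccc2[nH]ncc12)NC1CCOc2c1cccc2C(F)(F)F` gives 5 nM, beyond it. Within the data shown here, only one measured step touches the same position: a 3.0-fold higher number from compound 2 to compound 3 (0.48 log units; beyond the scatter). Compound 4 `O=C(Nc1cccc2[nH]ncc12)NC1CCOc2ccccc21` differs from compound 3 by hydrogen in place of cyclohexyl on an aromatic carbon. Among the measured compounds shown here, no measured step removes a group entirely at this position, so the forecast is loose. That one change at this position moved the number beyond the scatter, and compound 4 is expected to move further in the same direction, a 2.7-fold higher number from compound 3 to compound 4 (0.43 log units; beyond the scatter). Compound 4 is thus estimated at 40 nM, with a range from 10 nM to 160 nM.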

Compound 4, half-maximal inhibitory concentration: 234 nM
Estimate against measurement, compound 4: 5.9-fold (0.77 log units) below, and the stated range ends below it.
By their numbers in this assay, from the lowest: compounds 2, 1 and 3 (each within the scatter of the next, the first and the last beyond it); then compound 4.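

In this assay, within the data shown here, the earlier compounds compared one group only with another, while compound 4 shows what plain hydrogen gives. Hydrogen in place of each group raises the number sharply: a 16-fold higher number from compound 3 to compound 4 (1.19 log units; beyond the scatter) for cyclohexyl, a 47-fold higher number from compound 2 to compound 4 (1.67 log units; beyond the scatter) for trifluoromethyl and a 29-fold higher number from compound 1 to compound 4 (1.47 log units; beyond the scatter) for trifluoromethoxy. Having a group on this aromatic carbon therefore counts for more than the choice between cyclohexyl and trifluoromethyl. Nothing available explains the size of these steps. From the compounds shown here alone, whether a methyl group, a chlorine atom or an amine would restore the lower numbers stays open.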